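Swapping the aryl ring at the double-bonded carbon

A few compounds are considered here, and "the series" means these few. Any claim that something is new, unique, unknown or untested is made for them only; others in the source may bear on it.

Measured in a functional assay on HL-60 cells (Homo sapiens) for cytotoxicity, read by CCK-8 assay, with a stated time of 72 h; on this read-out lower numbers stand for stronger inhibition and higher numbers for weaker inhibition:
Compound 1, `C=CCn1c(=O)/c(=C\c2cccc(F)c2)[nH]c(=O)/c1=C\c1ccccc1OC`: 8890 nM
Compound 2, `C=CCn1c(=O)/c(=C\c2cc(Br)ccc2F)[nH]c(=O)/c1=C\c1ccccc1OC`: 17400 nM

Among the compounds with values here, compound 2 stands at one end of this pair of numbers, but the only step connecting it to a neighbour, a 2.0-fold higher number from compound 1 to compound 2 (0.29 log units; within the scatter), is too small to tell the two compounds apart. Compound 3, `C=CCn1c(=O)/c(=C\c2ccc(C)cc2)[nH]c(=O)/c1=C\c1ccccc1OC`, keeps the shared core of compound 2 and changes one ring: 4-methylphenyl in place of 5-bromo-2-fluorophenyl on a double-bonded chain carbon bound to an aromatic carbon.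

Within the data shown here, the one step that bears on this change is the step from compound 1 to compound 2, which also exchanged the ring on the double-bonded chain carbon bound to an aromatic carbon, and which stayed within the scatter. Among the measured compounds shown here, no measured compound carries a 4-methylphenyl group, so its effect is unknown. On this basis the expectation is no step beyond the scatter, so a 1.5-fold lower number from compound 2 to compound 3 (0.16 log units; within the scatter) is expected to be small. Compound 3 is estimated to give about 12000 nM in this assay, expected to lie between 4000 nM and 40000 nM.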

Compound 3, half-maximal inhibitory concentration: "not active" (no number reported)
Compound 3 has no reported number here; there is nothing to compare the estimate with.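

Within the data shown here, compound 3 is reported as "not active" in this assay, with no number, so no step from compound 2 to compound 3 can be read. The compounds shown leave open how the 4-methylphenyl group of compound 3 compares in size of effect with the 5-bromo-2-fluorophenyl group of compound 2. No supporting evidence bears on this result.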